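The compounds below may be only part of what the source reports. "The series", "measured", "known", "first", "only" and "open" are said of these compounds alone.

Compound 1 `CC(C)NC(=O)[C@H]1CC[C@@H](n2/c(=N/C(=O)c3ccc(F)cc3)[nH]c3ccc(CN4CC(C(C)(C)O)C4)cc32)CC1`: < 14 mL.min-1.g-1, a limit of the assay and not a number
Compound 2 `CC(C)NC(=O)[C@H]1CC[C@@H](n2/c(=N/C(=O)c3ccc(F)cc3)[nH]c3ccc(CN4CCCCC4)cc32)CC1`: 451 mL.min-1.g-1
Compound 3 `CC(C)NC(=O)[C@H]1CC[C@@H](n2/c(=N/C(=O)c3cccc(C#N)c3)[nH]c3ccc(CN4CCC(C(C)(C)O)CC4)cc32)CC1`: 17 mL.min-1.g-1

In an in vitro ADME assay on microsomes from liver (Rattus norvegicus) for metabolic stability (on this read-out lower numbers stand for slow clearance and higher numbers for fast clearance), compound 3 gives 17 mL.min-1.g-1, the lowest actual number, while compound 2 stands far higher at 451 mL.min-1.g-1. Compound 4 `CC(C)NC(=O)[C@H]1CC[C@@H](n2/c(=N/C(=O)c3cccnc3)[nH]c3ccc(CN4CCC(C(C)(C)O)CC4)cc32)CC1` carries pyridin-3-yl in place of 3-cyanophenyl on a carbonyl carbon. Within the data shown here, the one measured step, an at least 32-fold higher number from compound 1 to compound 2 (1.50 log units; beyond the scatter), is large, but it lies on a saturated chain carbon bound to an aromatic carbon, not on the carbonyl carbon. The expectation therefore rests on compound 3 at 17 mL.min-1.g-1. The expected step, a 1.1-fold lower number from compound 3 to compound 4 (0.03 log units; within the scatter), stays within the scatter, with no clear direction. Compound 4 is estimated at 16 mL.min-1.g-1, within a range of 9 mL.min-1.g-1 to 35 mL.min-1.g-1.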

Compound 4, intrinsic clearance in microsomes: < 14 mL.min-1.g-1
Compound 4 gave a limit, no number; the forecaster's own chance of this, stated with the estimate: 35%; middle value at least 1.1-fold (0.05 log units) from the limit.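

Among these compounds, compound 3 and compound 4 differ only in the group on the carbonyl carbon, so this is the first reading of that position, and in this assay the swap of 3-cyanophenyl for pyridin-3-yl gives an at least 1.2-fold lower number from compound 3 to compound 4 (0.08 log units; that floor lies within the scatter). The value of compound 4 is a limit of the assay and not a number. Only a floor can be given for this step, because the read-out stops at a limit: the limit of < 14 mL.min-1.g-1 in this assay, at which 2 of the 4 values shown sit.

From the compounds shown here alone, how a pyrimidin-5-yl or a 3-aminophenyl group would read on this carbonyl carbon remains open. So does whether pyridin-3-yl would give a readable number alongside the piperidin-1-yl of compound 2.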